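Chain branching on the side chain of the glucagon series

A few compounds are considered here, and "the series" means these few. Any claim that something is new, unique, unknown or untested is made for them only; others in the source may bear on it.

Compound 1 `CCC[C@H](c1ccc(C(=O)NCc2nn[nH]n2)cc1)N1C(=O)C(c2cc(Cl)cc(Cl)c2)=N[C@]12CC[C@@H](C(C)(C)C)CC2` and compound 2 `CCCCC[C@H](c1ccc(C(=O)NCc2nn[nH]n2)cc1)N1C(=O)C(c2cc(Cl)cc(Cl)c2)=N[C@]12CC[C@@H](C(C)(C)C)CC2` share the same core and differ only in the chain on the saturated carbon. In an assay on membranes from liver for displacement of a labelled ligand from Glucagon receptor (Mus musculus), read by scintillation counting, with a stated time of 60 min (on this read-out higher numbers stand for weaker inhibition and lower numbers for stronger inhibition), compound 1 gives 500 nM, and compound 2 gives 310 nM. For the measured compounds named here, the step of a 1.6-fold lower number from compound 1 to compound 2 (0.21 log units; within the scatter) is the only measured step in the set. Compound 2 stands at the lower of the two numbers, with compound 1 nearest, though the gap between them is inside the scatter, so no order between them is claimed.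

Compound 3 `CC(C)CC[C@H](c1ccc(C(=O)NCc2nn[nH]n2)cc1)N1C(=O)C(c2cc(Cl)cc(Cl)c2)=N[C@]12CC[C@@H](C(C)(C)C)CC2` keeps the same atoms as compound 2 but joins them differently: isopropyl in place of propyl on a saturated chain carbon, three bonds along the chain from an amide-type nitrogen in a ring and an aromatic carbon. Going by the values given here, the one measured step bears on it only loosely, since it changed the length of the chain, not its branching, and it stayed within the scatter. No step beyond the scatter is therefore expected; the step of a 1.0-fold lower number from compound 2 to compound 3 (0.01 log units; within the scatter) is estimated to be flat. Compound 3 is expected to give about 300 nM in this assay, within 130 nM to 700 nM.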

Compound 3, half-maximal inhibitory concentration: 280 nM
Beside the measured number, compound 3's estimate is 1.1-fold (0.03 log units) above it, within the range that was stated.
By their numbers in this assay, from the lowest: compounds 3, 2 and 1 (each within the scatter of the next).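

In this assay, branching the chain on the saturated carbon gives a 1.1-fold lower number from compound 2 to compound 3 (0.04 log units; within the scatter), so isopropyl in place of propyl, three bonds along the chain from an amide-type nitrogen in a ring and an aromatic carbon, leaves the reading flat. The wider comparison gives a 1.8-fold lower number from compound 1 to compound 3 (0.25 log units; within the scatter), so neither this branched chain nor the unbranched chain of compound 2 separates from compound 1. No measurement here bears on why the reading stays flat.

On these data alone, whether a larger change on this carbon would move the number beyond the scatter stays open, for instance a longer chain such as heptyl or a ring such as cyclohexyl. Across compounds 1, 2 and 3 the chain holds only carbon, so the compounds shown say nothing about an amine or a carboxylic acid at its end.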